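Swapping a Methylphenyl Arm for a Methoxyphenyl Arm

A few compounds are considered here, and "the series" means these few. Any claim that something is new, unique, unknown or untested is made for them only; others in the source may bear on it.

Measured compounds:
compound 1, `C=CCn1c(=O)/c(=C\c2cccc(C)c2)[nH]c(=O)/c1=C\c1ccccc1OC`: 22700 nM
compound 2, `C=CCn1c(=O)/c(=C\c2cc(F)ccc2C)[nH]c(=O)/c1=C\c1ccccc1OC`: 4900 nM

Among the measured compounds shown here, in a functional assay on A549 cells (Homo sapiens) for cytotoxicity, read by CCK-8 assay, with a stated time of 72 h (a higher number here means a weaker inhibitor, a lower number a stronger inhibitor), compound 1 gives 22700 nM, the highest of the two numbers available; its only neighbour is compound 2, and the change between them is a 4.6-fold lower number from compound 1 to compound 2 (0.67 log units; beyond the scatter). Compound 3, `C=CCn1c(=O)/c(=C\c2ccccc2OC)[nH]c(=O)/c1=C\c1ccccc1OC`, has not yet been measured. It differs from compound 1 in one place: 2-methoxyphenyl in place of 3-methylphenyl on a double-bonded chain carbon bound to an aromatic carbon. For the measured compounds named here, the one measured step, a 4.6-fold lower number from compound 1 to compound 2 (0.67 log units; beyond the scatter), introduced a different group at the same place, so it bears on the present change only loosely, showing that this arm of the shared core can move the number beyond the scatter. On that basis a modest move downward is expected for compound 3, a 1.9-fold lower number from compound 1 to compound 3 (0.28 log units; within the scatter), while a result within the scatter of compound 1 would not surprise. Compound 3 is therefore estimated at 12000 nM, with a range from 4000 nM to 40000 nM.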

Compound 3, half-maximal inhibitory concentration: 22400 nM
The estimate for compound 3 lay 1.9-fold (0.27 log units) below the measured number, and the stated range covers the measured number.
By their numbers in this assay, from the lowest: compound 2; then compounds 3 and 1 (each within the scatter of the next).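

In this assay, 2-methoxyphenyl on a double-bonded chain carbon bound to an aromatic carbon reads the same as 3-methylphenyl (a 1.0-fold lower number from compound 1 to compound 3 (0.01 log units; within the scatter)), so a new oxygen and hydrogen-bond acceptor on this arm leave the number within the scatter. The place therefore does not answer to every replacement: among the three arms shown, only 5-fluoro-2-methylphenyl stands apart, and it does so from 2-methoxyphenyl as well (a 4.6-fold higher number from compound 2 to compound 3 (0.66 log units; beyond the scatter)), by about as much as from 3-methylphenyl. Nothing available accounts for this result.

The compounds shown cannot tell whether the fluorine or the different methyl placement in compound 2 carries its lower number, as that arm differs from the arm of compound 1 in both. From the compounds shown here alone, how an amine or a carboxylic acid on this arm would read also remains open.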